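The source may report more compounds than this note shows. Statements on the series, on what has been measured and on what is new or still open speak of the compounds shown alone.

Measured so far in a functional assay on Lu1 cells (Homo sapiens) for cytotoxicity; a higher number here means that more compound is needed for the effect, a lower number that less compound is needed:
- compound 2 `CCCCC1=C(Br)/C(=C/Br)OC1=O`: > 20 ug/mL
- compound 1 `CCC[C@@H](OC(C)=O)C1=C(Br)[C@@](C)(OC)OC1=O`: > 20 ug/mL
- compound 3 `CCC[C@@H](O)C1=C(Br)C(=C(Br)Br)OC1=O`: 1.7 ug/mL

Compound 2 stands at a limit of this assay, not at a number. Compound 1 likewise gives only a limit, > 20 ug/mL. The shared point is the limit of > 20 ug/mL in this assay, at which 2 of the 3 values shown sit, so the standing of compound 2 against compound 1 cannot be ranked. Among the compounds with values here, compound 3 is the only entry with a number, 1.7 ug/mL; it differs from compound 2 in more than one place, so no single step connects them and nothing can be said of which change carries the difference.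

Compound 4 `CCC[C@@H](O)C1=C(Br)/C(=C/Br)OC1=O` is the next entry for this assay. Against compound 2 the change is hydroxy in place of hydrogen on a saturated chain carbon bound to a double-bonded ring carbon and a saturated chain carbon. Within the data shown here, no step between measured compounds shows what this change does on its own. Among the measured compounds shown here, the one compound with a hydroxy on the chain, compound 3, gives 1.7 ug/mL. Compound 2 sits at a limit of this assay. That is the only pointer, and it is indirect.

For compound 4 the expectation is therefore a lower concentration than the limit of compound 2, with wide uncertainty. Compound 4 is estimated at 6 ug/mL, ranging from 1.5 ug/mL to 20 ug/mL. The step expected is an at least 3.3-fold lower number from compound 2 to compound 4 (0.52 log units; beyond the scatter), a move beyond the scatter toward less compound needed.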

Compound 4, concentration for half-maximal effect: 0.3 ug/mL
Compound 4: middle estimate off by 20-fold (1.30 log units), on the high side, outside the stated range (below it).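

In this assay, within the data shown here, this pair gives the first direct reading of hydroxy in place of hydrogen on a saturated chain carbon bound to a double-bonded ring carbon and a saturated chain carbon: an at least 66-fold lower number from compound 2 to compound 4 (1.82 log units; beyond the scatter). Compound 2 gives only a limit, > 20 ug/mL, and not a number. The step is therefore a minimum for this single change, which is enough to show that this chain carbon is a place where one substitution separates a compound at the limit from one with a measured value, and the reading rests on this shared limit: the limit of > 20 ug/mL in this assay, at which 2 of the 4 values shown sit.

The compounds shown leave open whether the free hydroxy is required on this carbon, or whether an amine or a carbonyl on the same carbon would give a similar reading, and whether the opposite configuration there would do the same. They also leave open how a longer chain behaves with the hydroxy kept in place, and whether the change holds on the core of compound 3 , which gives 1.7 ug/mL with its hydroxy present but has no partner lacking it.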